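A Tert-Butyl Relative of Two Compounds at the Assay Limit

The source may report more compounds than this note shows. Statements on the series, on what has been measured and on what is new or still open speak of the compounds shown alone.

Compound 1 `CCOC(=O)C12C(=O)OCC=C1COC2c1ccccc1` was examined in a functional assay on A549 cells (Homo sapiens) for cytotoxicity, read by MTT assay; on this read-out higher numbers stand for weaker inhibition and lower numbers for stronger inhibition. In this assay compound 1 gives only a limit, > 1000000 nM, and not a number. Its closest measured companion is compound 2 `CCOC(=O)C12C(=O)OCC=C1COC2c1ccc(Cl)c(Cl)c1`. In this assay compound 2 likewise gives only a limit, > 1000000 nM. Going by the values given here, both measured values therefore rest at the limit of > 1000000 nM in this assay, at which 2 of the 2 values shown sit, so compound 1 stands exactly where the only other measured compound stands, and no step between measured compounds can be sized from these two limits.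

Compound 3 `CCOC(=O)C12C(=O)OCC=C1COC2c1ccc(C(C)(C)C)cc1` is the next compound to be tested. It differs from compound 1 by tert-butyl in place of hydrogen on an aromatic carbon. Because both measured compounds sit at the limit of > 1000000 nM in this assay, at which 2 of the 2 values shown sit, there is no measured direction to follow. The expected step of a number no higher from compound 1 to compound 3 (the limit leaves the size open) is none beyond the scatter, with compound 3 expected to remain at the limit as well. Compound 3 is estimated at 1000000 nM in this assay, within a range from 200000 nM to 5000000 nM, most likely reported as a limit rather than a number.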

Compound 3, half-maximal inhibitory concentration: > 1000000 nM
Compound 3: no number, only a limit (the forecaster's own chance of this, stated with the estimate: 85%); the middle value lies on the limit itself.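

In this assay compound 3 gives > 1000000 nM, which is a limit and not a number. Compound 1 also gives only a limit, so no step can be read between compound 1 and compound 3: the limit of > 1000000 nM in this assay, at which 3 of the 3 values shown sit. The compounds shown leave open whether any change to the shared core would give a measurable number in this assay.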